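A few compounds are considered here, and "the series" means these few. Any claim that something is new, unique, unknown or untested is made for them only; others in the source may bear on it.

Measured so far in an ADME assay on CCRF-CEM cells (Homo sapiens) for cytotoxicity, with a stated time of 72 h; a lower number here means a stronger inhibitor, a higher number a weaker inhibitor:
compound 1, `Cc1ccc(-c2cn3nc(Cc4ccc(Cl)cc4)sc3n2)cc1`, gives only a limit of the assay, > 250000 nM.
compound 2, `Clc1ccc(Cc2nn3cc(-c4ccc(Cl)cc4Cl)nc3s2)cc1`, likewise gives only a limit of the assay, > 250000 nM.
compound 3, `Cc1ccc(-c2nc3sc(Cc4ccc(Cl)cc4)nn3c2SC#N)cc1`, gives a number, 22000 nM.

The change from compound 1 to compound 2 is 2,4-dichlorophenyl in place of 4-methylphenyl on an aromatic carbon. Its step is a step that the two limits leave unreadable from compound 1 to compound 2, since both compounds sit at the limit of > 250000 nM in this assay, at which 2 of the 3 values shown sit. The two cores differ by cyanosulfanyl in place of hydrogen on an aromatic carbon, which gave an at least 11-fold lower number from compound 1 to compound 3 (1.05 log units; beyond the scatter).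

Compound 4, `N#CSc1c(-c2ccc(Cl)cc2Cl)nc2sc(Cc3ccc(Cl)cc3)nn12`, is not yet measured. It carries the same kind of change on the core of compound 3: 2,4-dichlorophenyl in place of 4-methylphenyl on an aromatic carbon. The surroundings differ in that the place in compound 4 is also next to the ring atom that bears a cyanosulfanyl group. Because a step that the two limits leave unreadable from compound 1 to compound 2 stays unreadable, the earlier step gives no measure of size, so the expectation for compound 4 rests mainly on compound 3 at 22000 nM and a step of about a 1.4-fold higher number from compound 3 to compound 4 (0.13 log units; within the scatter) is expected, within the usual scatter. Compound 4 is therefore estimated at 30000 nM, between 8000 nM and 120000 nM.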

Compound 4, half-maximal inhibitory concentration: 46000 nM
The estimate for compound 4 lay 1.5-fold (0.19 log units) below the measured number; low and high end bracket the measured number.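

In this assay, the cyanosulfanyl group again lowers the number on the core bearing 2,4-dichlorophenyl, with an at least 5.4-fold lower number from compound 2 to compound 4 (0.73 log units; beyond the scatter), so the direction of this change carries from one core to the other: the same change on two cores in this assay, an at least 11-fold lower number (1.05 log units; beyond the scatter) from compound 1 to compound 3 and an at least 5.4-fold lower number (0.73 log units; beyond the scatter) from compound 2 to compound 4; the limit leaves it open whether they differ. From the compounds shown here alone, compound 1 and compound 2 each give only a limit of the assay, so the true size of the change on either core remains unknown: the limit of > 250000 nM in this assay, at which 2 of the 4 values shown sit. The swap of 4-methylphenyl for 2,4-dichlorophenyl can be read only with the cyanosulfanyl group in place, as a 2.1-fold higher number from compound 3 to compound 4 (0.32 log units; beyond the scatter), while the matching step between the two limit compounds cannot be read, so this result does not show whether the swap behaves alike without that group.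

The compounds shown leave open whether another group in place of hydrogen on that aromatic carbon, such as methylsulfanyl, an amine or a carboxylic acid, would also lower the number. They also leave open whether the direction of the change holds on cores beyond these two.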